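The compounds below may be only part of what the source reports. "The series", "measured", "known", "first", "only" and "open" are said of these compounds alone.

In an ADME assay on MT4 cells (Homo sapiens) for cytotoxicity (on this read-out lower numbers stand for higher toxicity in this test and higher numbers for lower toxicity in this test), three thioureas have been measured. Compound 1 `C=C(C)CNC(=S)Nc1cccc(C(F)(F)F)c1` gives 43000 nM, compound 2 `CCCCc1ccc(NC(=S)Nc2cccc(C(F)(F)F)c2)c(C)c1` gives 43000 nM, and compound 3 `CCOC(=O)c1ccc(NC(=S)Nc2cccc(C(F)(F)F)c2)cc1` gives 23000 nM. The three numbers sit close together: the gap from compound 3 to compound 1 and the gap from compound 3 to compound 2 both lie within the usual scatter, so the numbers of compound 3 cannot be set apart from the other two.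

Compound 4 `CCCC[C@H]1CC[C@H](c2ccc(NC(=S)Nc3cccc(C(F)(F)F)c3)cc2)CC1` has not yet been measured in this assay. Against compound 3 the change is 4-butylcyclohexyl in place of ethoxycarbonyl on an aromatic carbon. Going by the values given here, no measured pair shows this change, so its effect in this assay can only be guessed. Because compound 2 gives 43000 nM with a butyl chain on its aromatic ring, a larger hydrocarbon group on the shared core is not expected to move the number far. Compound 4 is therefore estimated at 20000 nM, with a range of 8000 nM to 50000 nM, an expected step of a 1.2-fold lower number from compound 3 to compound 4 (0.06 log units; within the scatter) that would stay within or just beyond the scatter.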

Compound 4, half-maximal cytotoxic concentration: 22000 nM
Compound 4: the middle estimate sits 1.1-fold (0.04 log units) below what was measured, and the stated range covers the measured number.
By their numbers in this assay, from the lowest: compounds 4, 3, 1 and 2 (each within the scatter of the next).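

In this assay, going by these compounds alone, 4-butylcyclohexyl in place of ethoxycarbonyl on an aromatic carbon, para to a large group, gives a 1.0-fold lower number from compound 3 to compound 4 (0.02 log units; within the scatter), the first step that can be read at this position. At this position, then, a group of 10 heavy atoms, all carbon, with a non-aromatic ring and no hydrogen-bond acceptors, cannot be told apart from a group of 5 heavy atoms with 2 hydrogen-bond acceptors and no ring. No measurement shown here bears on why the two groups read alike. On these data alone, what a charged group at this position, such as an amine or a carboxylic acid, would give remains open. So does the reading of the other stereoisomer of the 4-butylcyclohexyl group, and whether this change would give the same step on another thiourea.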